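The source may hold more compounds than are shown below. What is called first, only, known or untested is meant among the compounds shown, and "the series" means these compounds.

Measured compounds and their numbers:

Compound 1 `CN1CCN(Cc2nnc(-c3cc(S(N)(=O)=O)c(SCc4ccccc4)cc3Cl)o2)CC1` gives 75000 nM in a functional assay on HeLa cells (Homo sapiens) for cytotoxicity, read by MTT assay, with a stated time of 72 h; on this read-out lower numbers stand for stronger inhibition and higher numbers for weaker inhibition.
Compound 2 `CCOC(=O)c1cn(Cc2nnc(-c3cc(S(N)(=O)=O)c(SCc4ccccc4)cc3Cl)o2)nn1` gives 122000 nM.
Compound 3 `CC(C)(O)c1cn(Cc2nnc(-c3cc(S(N)(=O)=O)c(SCc4ccccc4)cc3Cl)o2)nn1` gives 68000 nM.

Compound 2 carries the highest of these three numbers, but the gaps are small: a 1.6-fold higher number from compound 1 to compound 2 (0.21 log units; within the scatter) and a 1.8-fold lower number from compound 2 to compound 3 (0.25 log units; within the scatter) both lie within the scatter, as does a 1.1-fold lower number from compound 1 to compound 3 (0.04 log units; within the scatter). On these numbers the three compounds cannot be told apart.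

Compound 4 `NS(=O)(=O)c1cc(-c2nnc(/C=C/c3ccc(Br)cc3)o2)c(Cl)cc1SCc1ccccc1` differs from compound 2 in one place: 2-(4-bromophenyl)ethenyl in place of (4-(ethoxycarbonyl)-1H-1,2,3-triazol-1-yl)methyl on an aromatic carbon. The measured steps only exchanged the group on the saturated chain carbon bound to an aromatic carbon, or changed the group on an aromatic carbon of that part; none removed the whole (4-(ethoxycarbonyl)-1H-1,2,3-triazol-1-yl)methyl or introduced a 2-(4-bromophenyl)ethenyl. So no measured step bears directly on this change; they show only that varying this part left the number within the scatter. I therefore expect no step beyond the scatter, with a wide range because the change is untested. Compound 4 is expected to give 80000 nM, between 20000 nM and 300000 nM. This estimate means an expected step of a 1.5-fold lower number from compound 2 to compound 4 (0.18 log units; within the scatter).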

Compound 4, half-maximal inhibitory concentration: 29000 nM
Compound 4: the middle estimate sits 2.8-fold (0.44 log units) above what was measured; the measured number falls inside the stated range.
By their numbers in this assay, from the lowest: compound 4; then compounds 3, 1 and 2 (each within the scatter of the next).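

At this position, on the five-membered aromatic ring with 2 nitrogen and 1 oxygen, 2-(4-bromophenyl)ethenyl gives the first separation in this assay: there is a 4.2-fold lower number from compound 2 to compound 4 (0.62 log units; beyond the scatter) and a 2.3-fold lower number from compound 3 to compound 4 (0.37 log units; beyond the scatter) and also a 2.6-fold lower number from compound 1 to compound 4 (0.41 log units; beyond the scatter). The earlier compounds shown here could not be told apart, so this result shows that a change here can move the number beyond the scatter, though only modestly, and that it does so against all three groups it replaces. Nothing measured here explains this difference.

Going by these compounds, the entering group brings a bromine, a carbon-only aromatic ring and an ethenyl link together, so their separate contributions remain open. A plain 2-phenylethenyl group would test the bromine, and a saturated 2-(4-bromophenyl)ethyl group would test the double bond.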